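Alkyne tail: lactam swapped for methoxy-bearing branch

The source may report more compounds than this note shows. Statements on the series, on what has been measured and on what is new or still open speak of the compounds shown alone.

Compound 3 `NC(=O)c1cc(Cl)c2c(Cl)c(C#CCN3CCCC3=O)n([C@H]3CCCNC3)c2n1` stands second highest of the three numbers measured in a functional assay on KG-1 cells (Homo sapiens) for antiproliferative activity (a lower number here means that less compound is needed, a higher number that more compound is needed for the effect), giving 178 nM; compound 1 `NC(=O)c1cc(Cl)c2c(Cl)c(C#CCO)n([C@H]3CCCNC3)c2n1` gives 301 nM and compound 2 `COCCC#Cc1c(Cl)c2c(Cl)cc(C(N)=O)nc2n1[C@H]1CCCNC1` gives 39 nM. Compound 4 `COC(C)(C)CC#Cc1c(Cl)c2c(Cl)cc(C(N)=O)nc2n1[C@H]1CCCNC1` differs from compound 3 by 1-methoxy-1-methylethyl in place of 2-oxopyrrolidin-1-yl on a saturated chain carbon bound to a triple-bonded carbon. Within the data shown here, two measured steps bear on this change: a 4.6-fold higher number from compound 2 to compound 3 (0.66 log units; beyond the scatter), and a 7.7-fold lower number from compound 1 to compound 2 (0.89 log units; beyond the scatter), both beyond the scatter and both in favour of the methoxy-containing tail. The step of a 1.7-fold lower number from compound 1 to compound 3 (0.23 log units; within the scatter) lies within the scatter. Because compound 2 gives 39 nM with its methoxy-containing tail, a modest step down is expected for compound 4, a 3.0-fold lower number from compound 3 to compound 4 (0.47 log units; beyond the scatter). For compound 4 the estimated value in this assay is 60 nM, within a range of 25 nM to 150 nM.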

Compound 4, half-maximal effective concentration: 172 nM
Compound 4: the middle estimate sits 2.9-fold (0.46 log units) below what was measured, outside the stated range (above it).
By their numbers in this assay, from the lowest: compound 2; then compounds 4, 3 and 1 (each within the scatter of the next).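

In this assay, the 1-methoxy-1-methylethyl group does not match the methoxymethyl group on a saturated chain carbon bound to a triple-bonded carbon (a 4.4-fold higher number from compound 2 to compound 4 (0.64 log units; beyond the scatter)), so a methoxy group in the tail does not alone secure the low number of compound 2. Compound 4 cannot be told apart from the lactam (a 1.0-fold lower number from compound 3 to compound 4 (0.01 log units; within the scatter)) or the hydroxy compound (a 1.8-fold lower number from compound 1 to compound 4 (0.24 log units; within the scatter)). Nothing available explains the gap between the two methoxy-bearing tails.

Going by these compounds, whether a single methyl group on that chain already raises the number remains open. So does how an amine or a carboxylic acid in this place would compare.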